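Methionine-type acid to lysine-type acid

This account rests on a few compounds, and the source may have more. Where it says the series, first, only, none or still open, it means among the compounds named here.

Of the compounds shown here, three have so far been measured in a functional assay on the whole organism (Tail, strain ICR) with Mus musculus as the target, in the tail flick test, with a stated time of 150 min, at a dose of 25 umol/kg by the oral route; a lower number here means a weaker effect, a higher number a stronger effect of the compound at the dose given. Compound 1 `CSCC[C@H](NC(=O)CN(c1nc(Cl)nc2[nH]cnc12)C1CC1)C(=O)OCc1ccccc1` gives 17.6%, compound 3 `NC(=O)C[C@H](NC(=O)CN(c1ncnc2c1ncn2C1CCCCO1)C1CC1)C(=O)OCc1ccccc1` gives 21.7%, and compound 2 `CSCC[C@H](NC(=O)CN(c1nc(Cl)nc2[nH]cnc12)C1CC1)C(=O)O` gives 4.14%, the lowest of the three numbers. Within the data shown here, the only step between two measured compounds, a number 13.5 percentage points lower from compound 1 to compound 2 (beyond the scatter), concerns the ester end of the molecule and not the side chain. Compound 4 `NCCCC[C@H](NC(=O)CN(c1nc(Cl)nc2[nH]cnc12)C1CC1)C(=O)O` differs from compound 2 in that side chain: 2-aminoethyl in place of methylsulfanyl on a saturated chain carbon, three bonds along the chain from an amide-type nitrogen and a carbonyl carbon. No measured step bears on this change, so nothing shown here speaks for a move in either direction, and compound 2 already stands low. The expected step is therefore a number 2.9 percentage points higher from compound 2 to compound 4 (within the scatter), within the scatter. Compound 4 is accordingly estimated at about 7%, between 0% and 20%.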

Compound 4, a percentage reported as activity, at one dose (the size of the read-out at that dose, not a potency): 11.6%
The estimate for compound 4 lay 4.6 percentage points below the measured number; the range from low to high includes it.
By their numbers in this assay, from the lowest: compounds 2, 4, 1 and 3 (each within the scatter of the next, the first and the last beyond it).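

In this assay, among these compounds, 4-aminobutyl in place of 2-(methylsulfanyl)ethyl on the free acid gives a number 7.5 percentage points higher from compound 2 to compound 4 (within the scatter) as the first measured step at this side chain, so the exchange of a sulfur-bearing chain for an amine-bearing one does not move the read-out beyond the scatter. No measured evidence bears on this result.
Among the compounds shown here, it remains open whether a benzyl ester on compound 4 would give a step like the one between compound 1 and compound 2, and whether a carboxylic acid at the end of the chain, in place of the amine, would read differently.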